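Swapping benzyl for 4-fluorophenyl in compound 2

A few compounds are considered here, and "the series" means these few. Any claim that something is new, unique, unknown or untested is made for them only; others in the source may bear on it.

For the measured compounds named here, in a functional assay on KB-V1 cells (Homo sapiens) for cytotoxicity, read by MTT assay, with a stated time of 72 h (on this read-out lower numbers stand for stronger inhibition and higher numbers for weaker inhibition), compound 2 (`O=C1Nc2ccccc2/C1=N/NC(=S)NCc1ccccc1`) gives 7630 nM and holds the higher of the two numbers so far. Compound 1 (`O=C1Nc2ccccc2/C1=N/NC(=S)Nc1cccc2ccccc12`) reads lower at 2210 nM and the gap lies beyond the scatter. Compound 3 (`O=C1Nc2ccccc2/C1=N/NC(=S)Nc1ccc(F)cc1`) carries 4-fluorophenyl in place of benzyl on an amide-type nitrogen. Going by the values given here, no measured step isolates this change, and the only guide is compound 1 at 2210 nM on the lower side. In this assay a modest fall is therefore expected (a 1.8-fold lower number from compound 2 to compound 3 (0.26 log units; within the scatter)) at about the edge of the scatter. Compound 3 is estimated to read 4200 nM (1600 nM to 11000 nM).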

Compound 3, half-maximal inhibitory concentration: 1920 nM
The estimate for compound 3 lay 2.2-fold (0.34 log units) above the measured number, within the range that was stated.
By their numbers in this assay, from the lowest: compounds 3 and 1 (each within the scatter of the next); then compound 2.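

In this assay, for the compounds shown here, 4-fluorophenyl in place of benzyl on the amide-type nitrogen gives a 4.0-fold lower number from compound 2 to compound 3 (0.60 log units; beyond the scatter), the first measured step at this position. The two groups match in heavy atoms and in aromatic rings, yet the step lies beyond the scatter, so this position responds to the change. No measurement here accounts for the step. On these data alone, what stays open is whether the fluorine or the loss of the benzyl carbon carries it, which a plain phenyl on this nitrogen would help to separate. As far as these compounds go, how a methoxy group or an amine on that ring would read also stays open.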